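Removing a Nitro Group: Expected Tolerance on Vero Cells

The compounds below may be only part of what the source reports. "The series", "measured", "known", "first", "only" and "open" are said of these compounds alone.

Of the compounds shown here, three sharing a core have been tested in an ADME assay on Vero cells (Chlorocebus sabaeus) for cytotoxicity; a lower number here means that less compound is tolerated, a higher number that more compound is tolerated. Compound 1 `CC(=O)Nc1ccc(-c2nc3cc([N+](=O)[O-])ccc3[nH]2)cc1` bears a nitro group on the fused part of the core and an acetamide on the attached ring. In this assay compound 1 gives > 100000 nM, which is a limit of the test rather than a number. Compound 2 `CC(=O)Nc1ccc(-c2nc3ccccc3[nH]2)cc1` differs from it by hydrogen in place of nitro on an aromatic carbon. In this assay compound 2 also gives > 100000 nM, again a limit. The step that the two limits leave unreadable from compound 1 to compound 2 therefore cannot be sized. Compound 3 `O=[N+]([O-])c1ccc(-c2nc3ccccc3[nH]2)c([N+](=O)[O-])c1` carries two nitro groups on the attached ring; the difference between its core and that of compound 1 is not broken down here. In this assay compound 3 gives > 100000 nM, once more a limit. Across the set, (the limit of > 100000 nM in this assay, at which 3 of the 3 values shown sit), so no compound has yet shown a measurable toxic concentration.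

Compound 4 `O=[N+]([O-])c1ccccc1-c1nc2ccccc2[nH]1` is not yet measured. Relative to compound 3 it shows (hydrogen in place of nitro on an aromatic carbon). This is the same kind of change as from compound 1 to compound 2, but the surroundings differ: there the position was part of a fused or bridged system of two rings, meta to a fused ring and para to a fused ring, whereas here it is meta to a nitro group and para to a group of 9 heavy atoms. Since the earlier removal a step that the two limits leave unreadable from compound 1 to compound 2 could not be sized and every value sits at the limit, the change gives no reason to expect a drop in tolerance. For compound 4 the expected step is a number no higher from compound 3 to compound 4 (the limit leaves the size open). The value expected for compound 4 in this assay is 100000 nM, between 50000 nM and 200000 nM, most likely reported again only as a limit.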

Compound 4, half-maximal cytotoxic concentration: > 100000 nM
Compound 4 was reported as a limit; the forecaster's own chance of this, stated with the estimate: 85%; the middle value sits exactly at the limit.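

Compound 3 and compound 4 are both reported only as limits in this assay, so the size of the step between them, hydrogen in place of nitro, cannot be read. The set as a whole stays in one place: the limit of > 100000 nM in this assay, at which 4 of the 4 values shown sit. The compounds shown leave open at what concentration any of them would become toxic, and whether removing a nitro group changes that concentration.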